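The source may hold more compounds than are shown below. What is called first, only, known or untested is meant among the compounds shown, and "the series" means these compounds.

Compound 1 `COc1ccc(/C=C/C(=O)CC(C)=O)cc1`: in a functional assay on MCF7 cells (Homo sapiens) for cytotoxicity, read by MTT assay, with a stated time of 72 h (on this read-out lower numbers stand for stronger inhibition and higher numbers for weaker inhibition), compound 1 gives 15800 nM.
Compound 2 `COc1ccc(/C=C/c2cc(C)no2)cc1`: compound 2 gives only a limit, > 100000 nM, in this assay.
Compound 3 `Cc1cc(/C=C/c2ccc(O)cc2)on1`: in this assay compound 3 gives 50200 nM.

Compound 2 is the one that sits at the limit of > 100000 nM in this assay, at which 1 of the 3 values shown sits. Compound 3 differs from it by one change, (hydrogen in place of methyl on an oxygen on an aromatic ring), and the step recorded is an at least 1.9-fold lower number from compound 2 to compound 3 (0.29 log units; that floor lies within the scatter). Compound 1 has a different core from compound 2; how the two cores differ is not broken down here. Of the two numbers given, compound 1 holds the lower, with compound 3 giving a higher number that lies beyond the scatter.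

Compound 4 `CC(=O)CC(=O)/C=C/c1ccc(O)cc1` has not yet been measured. It differs from compound 1 by the same change, (hydrogen in place of methyl on an oxygen on an aromatic ring), at the same place as the change from compound 2 to compound 3. Resting on the earlier step of an at least 1.9-fold lower number from compound 2 to compound 3 (0.29 log units; that floor lies within the scatter) from compound 2 to compound 3 and on the value of compound 1, 15800 nM, the expected step is a 1.6-fold lower number from compound 1 to compound 4 (0.20 log units; within the scatter). Compound 4 is therefore expected to give about 10000 nM in this assay, estimated between 4000 nM and 30000 nM.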

Compound 4, half-maximal inhibitory concentration: 19700 nM
Beside the measured number, compound 4's estimate is 2.0-fold (0.29 log units) below it; measured number inside the range.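

In this assay, exchanging methoxy for hydroxy on the core of compound 1 gives a 1.2-fold higher number from compound 1 to compound 4 (0.10 log units; within the scatter), so on this core compound 1 and compound 4 cannot be told apart and the change has no readable effect. Set beside the earlier case, the two cores compare as follows: the same change on two cores in this assay, an at least 1.9-fold lower number (0.29 log units; that floor lies within the scatter) from compound 2 to compound 3 and a 1.2-fold higher number (0.10 log units; within the scatter) from compound 1 to compound 4; the limit leaves it open whether they differ. This does not show that the change carries over from one core to the other, nor that it behaves differently on each, and the comparison stays unsettled at its starting point, where compound 2 gives only a limit, > 100000 nM.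

The compounds shown leave open how other groups would read in this assay at the same place on the aromatic ring, for instance an amine or a carboxylic acid in place of the hydroxy. They also leave open whether a longer chain on that oxygen, such as ethoxy or propoxy in place of methoxy, would give a step beyond the scatter on either core.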